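A Halogen Swap on a Compound Sitting at the Limit

The source may report more compounds than this note shows. Statements on the series, on what has been measured and on what is new or still open speak of the compounds shown alone.

Compound 1 `COc1cccc(CNc2ncnc3c2ncn3[C@@H]2O[C@H](CO)[C@@H](O)[C@H]2O)c1OC` and compound 2 `OC[C@H]1O[C@@H](n2cnc3c(NCc4ccc(F)c(F)c4F)ncnc32)[C@H](O)[C@@H]1O` share a core and differ only in the aryl group on the chain carbon. In a functional assay on MCF cells (Homo sapiens) for antiproliferative activity, with a stated time of 72 h (a higher number here means a weaker inhibitor, a lower number a stronger inhibitor), compound 1 gives > 166000 nM, which is a limit and not a number. Compound 2 gives > 166000 nM in this assay, again a limit and not a number. So far the record holds only (the limit of > 166000 nM in this assay, at which 2 of the 2 values shown sit).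

Compound 3 `OC[C@H]1O[C@@H](n2cnc3c(NCc4ccc(F)c(Cl)c4)ncnc32)[C@H](O)[C@@H]1O` carries 3-chloro-4-fluorophenyl in place of 2,3,4-trifluorophenyl on a saturated chain carbon bound to a nitrogen on an aromatic ring.

Going by the values given here, only one measured step bears on this change, a step that the two limits leave unreadable from compound 1 to compound 2, and it offers no size to carry over. That step replaced the aryl group and still produced no number, so a second aryl change is expected to leave the result where it stands, with no direction favoured. The expected step, a number no higher from compound 2 to compound 3 (the limit leaves the size open), should therefore not exceed the scatter. For compound 3 the estimate is 166000 nM, with an expected range of 70000 nM to 300000 nM, and another limit is the likeliest report.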

Compound 3, half-maximal inhibitory concentration: > 166000 nM
Compound 3: no number, only a limit; the forecaster's own chance of this, stated with the estimate: 75%; the middle value lies on the limit itself.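

Compound 3 gives > 166000 nM in this assay, which is a limit and not a number. Its steps from compound 1 and compound 2 therefore cannot be read. The compounds shown leave open whether any aryl group on the shared core gives a measurable value, because all of them stop at the same point: the limit of > 166000 nM in this assay, at which 3 of the 3 values shown sit.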